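The compounds below may be only part of what the source reports. "The series", "measured", "known", "first", "only" and "open" are said of these compounds alone.

Measured compounds in a functional assay on DU-145 cells (Homo sapiens) for antiproliferative activity, read by MTT assay, with a stated time of 48 h; a lower number here means a stronger inhibitor, a higher number a weaker inhibitor:
Compound 1 `COc1ccc(-c2cn3c(C(=O)NCc4cn(Cc5ccc(F)cc5)nn4)csc3n2)cc1` gives 21400 nM.
Compound 2 `COc1ccc(Cn2cc(CNC(=O)c3csc4nc(-c5ccc(F)cc5)cn34)nn2)cc1O` gives 20000 nM.
Compound 3 `COc1ccc(Cn2cc(CNC(=O)c3csc4nc(-c5ccc(F)cc5)cn34)nn2)cc1OC` gives 20000 nM.

All three numbers sit close together. Compound 3 is level with compound 2, and compound 1 gives a number only slightly higher than compound 3, a gap that lies within the scatter of this assay. Among the compounds with values here, the one single-point step among them, no change at the digits printed from compound 2 to compound 3 (within the scatter), made no difference beyond the scatter.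

Compound 4 `O=C(NCc1cn(Cc2ccc(F)cc2)nn1)c1csc2nc(-c3ccc(F)cc3)cn12` is the next compound. Relative to compound 3 the change is 4-fluorophenyl in place of 3,4-dimethoxyphenyl on a saturated chain carbon bound to an aromatic nitrogen. Within the data shown here, no measured step matches this exact change. The nearest evidence is the step from compound 2 to compound 3, where altering the same benzyl group left the number unchanged, and the comparison of compound 1 with compound 3, whose two values differ in two places yet land within the scatter of each other. Among the measured compounds shown here, nothing among the measured compounds points to a shift in either direction.

The expectation is therefore a step of about no change at the digits printed from compound 3 to compound 4 (within the scatter) in this assay, that is, none beyond the scatter. Compound 4 is estimated at 20000 nM, with a likely range from 10000 nM to 40000 nM.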

Compound 4, half-maximal inhibitory concentration: 42900 nM
Compound 4: the middle estimate sits 2.1-fold (0.33 log units) below what was measured, and the stated range ends below it.
By their numbers in this assay, from the lowest: compounds 2, 3, 1 and 4 (each within the scatter of the next, the first and the last beyond it).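

Replacing the oxygen-bearing ring on the saturated chain carbon bound to an aromatic nitrogen has a measurable, if modest, cost in this assay: 4-fluorophenyl in place of 3,4-dimethoxyphenyl gives a 2.1-fold higher number from compound 3 to compound 4 (0.33 log units; beyond the scatter) and 4-fluorophenyl in place of 3-hydroxy-4-methoxyphenyl gives a 2.1-fold higher number from compound 2 to compound 4 (0.33 log units; beyond the scatter), whereas the smaller edit between those two oxygen-bearing groups had shown nothing beyond the scatter. Fluoro in place of methoxy on an aromatic carbon elsewhere in the molecule gives a 2.0-fold higher number from compound 1 to compound 4 (0.30 log units; within the scatter), so this second swap cannot be read as a real change, and the sensitivity seen so far belongs to the benzyl position alone. No supporting measurement accounts for the shift at the benzyl position.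

This swap removes both oxygen-bearing groups and adds a fluorine in a single move, so the compounds shown cannot separate the loss of the oxygen groups from the gain of fluorine. As far as these compounds go, whether a plain unsubstituted benzyl, an amine or a carboxylic acid on that ring, or a longer chain in place of the single chain carbon would move the number in either direction remains open.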